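Chloro on a phenyl: one change, two cores

The source may hold more compounds than are shown below. What is called first, only, known or untested is meant among the compounds shown, and "the series" means these compounds.

Measured compounds:
- compound 1, `COc1ccc(C(=O)NO)cc1OCc1noc(-c2ccccc2)n1`, 36500 nM
- compound 2, `COc1ccc(C(=O)NO)cc1OCc1noc(-c2ccc(Cl)cc2)n1`, 21600 nM
- compound 3, `O=C(NO)c1cc(OCc2ccc(-c3ccccc3)cc2)no1`, 880 nM

In an assay on isolated protein for inhibition of sphingomyelin phosphodiesterase (Homo sapiens), read by fluorescence, with a stated time of 30 min (a higher number here means a weaker inhibitor, a lower number a stronger inhibitor), compound 1 gives 36500 nM and compound 2 gives 21600 nM. The two share a core and differ in one place: chloro in place of hydrogen on an aromatic carbon. The step between them is a 1.7-fold lower number from compound 1 to compound 2 (0.23 log units; within the scatter), so the two values cannot be told apart with confidence.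

Compound 3 stands on a different core, and in this assay compound 3 gives 880 nM, the lowest of the three numbers, clearly beyond the scatter from both compound 1 and compound 2. The difference between the two cores is not broken down here.

Compound 4, `O=C(NO)c1cc(OCc2ccc(-c3ccc(Cl)cc3)cc2)no1`, has not yet been measured. It is related to compound 3 in the same way that compound 2 is related to compound 1: chloro in place of hydrogen on an aromatic carbon. The place of the change is described in the same words for both pairs, so this is the same change made on another core.

The expectation for compound 4 rests on a single observation: compound 1 to compound 2 gave a 1.7-fold lower number from compound 1 to compound 2 (0.23 log units; within the scatter), a step within the scatter. On that basis the estimated step is a 1.5-fold lower number from compound 3 to compound 4 (0.17 log units; within the scatter), a small change at most. Compound 4 is therefore estimated at 600 nM, with a likely range from 250 nM to 1500 nM.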

Compound 4, half-maximal inhibitory concentration: 320 nM
Estimate against measurement, compound 4: 1.9-fold (0.27 log units) above, and the stated range covers the measured number.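

In this assay, putting chloro in place of hydrogen on an aromatic carbon, which turns a phenyl into a 4-chlorophenyl, gives a 2.8-fold lower number from compound 3 to compound 4 (0.44 log units; beyond the scatter), a modest step that can be told apart from the usual noise of repeated measurements. Comparing this with the same change on the core of compound 1, the two steps cannot be told apart, which is what would be expected if the change carries over between these cores with a similar size: the same change on two cores in this assay, a 1.7-fold lower number (0.23 log units; within the scatter) from compound 1 to compound 2 and a 2.8-fold lower number (0.44 log units; beyond the scatter) from compound 3 to compound 4, 1.6-fold (0.21 log units) apart, within the scatter of two such steps. Going by these compounds alone, this agreement rests on only two pairs, and the step on the core of compound 1 is too small to read with confidence on its own, so it shows neither a general rule for the series nor why chloro has the effect seen on the core of compound 3.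

The compounds shown leave open whether another group in place of that chloro, such as an amine, a carboxylic acid or a longer chain, would give a step of similar size on both cores. They also leave open whether the chloro change would hold on any third core, and how much each part of the difference between the two cores contributes to the gap in their numbers.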